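This account rests on a few compounds, and the source may have more. Where it says the series, first, only, none or still open, it means among the compounds named here.

Of the compounds shown here, three built on one shared core have been measured in an ADME assay on isolated protein for pharmacokinetics, with UDP-glucuronosyltransferase 1A9 (Homo sapiens) as the target, read by LC-MS, with a stated time of 60 min, at 37 degrees C, tested at 1 uM, in the presence of a further agent that is not named here; on this read-out lower numbers stand for a shorter-lived compound and higher numbers for a longer-lived compound. Compound 1 `CC1(C(=O)NCCSc2nonc2/C(=N/O)Nc2ccc(F)c(C(F)F)c2)CCN1` reaches only the limit of this assay, at > 3 h. Compound 3 `O=C(NCCSc1nonc1/C(=N/O)Nc1ccc(F)c(C(F)F)c1)C1CS(=O)(=O)C1` likewise stops at the limit, at > 3 h. The step from compound 1 to compound 3 in this assay, a step that the two limits leave unreadable from compound 1 to compound 3, swaps one four-membered ring on the carbonyl carbon for another, yet its size cannot be read because of the limit of > 3 h in this assay, at which 2 of the 3 values shown sit.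

For the measured compounds named here, compound 2 `C[C@H](CSc1nonc1/C(=N/O)Nc1ccc(F)c(Br)c1)NC(=O)CS(N)(=O)=O` is the one compound with a plain number: in this assay compound 2 gives 1.33 h, so it stands alone as the only readable point among the three.

Compound 4 `C[C@@H](CSc1nonc1/C(=N/O)Nc1ccc(F)c(Br)c1)NC(=O)CS(N)(=O)=O` keeps every atom and bond of compound 2 and differs only in configuration: the two compounds have the same atoms and bonds and differ only in configuration as drawn: 1 of 2 stereo elements differ; a stereocentre at a saturated chain carbon is drawn R in compound 2 and S in compound 4. Going by the values given here, no measured step touches this stereocentre, so nothing among the measured steps bears on the change, and no direction can be argued from them.

Compound 4 is therefore expected to show a step of a 1.1-fold higher number from compound 2 to compound 4 (0.02 log units; within the scatter), within the usual scatter. Compound 4 is estimated at 1.4 h, between 0.7 h and 2.8 h.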

Compound 4, half-life: > 3 h
Compound 4 ended at the assay's limit; the forecaster's own chance of this, stated with the estimate: 15%; middle value at least 2.1-fold (0.33 log units) away from the limit.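

In this assay, turning a stereocentre at a saturated chain carbon from R to S gives an at least 2.2-fold higher number from compound 2 to compound 4 (0.35 log units; beyond the scatter). The earlier step between compound 1 and compound 3 cannot be read, so this is the first readable step among the compounds shown, and it can be tied to that single stereocentre: the fact that compounds 2 and 4 differ only in the configuration as drawn. From the compounds shown here alone, the full size of the step stays unknown because compound 4 sits at a limit of the assay rather than at a number: the limit of > 3 h in this assay, at which 3 of the 4 values shown sit.

The compounds shown leave open whether the same change of configuration gives a similar step when a carboxylic acid or an amine stands on the chain in place of the present group. They also do not tell why this configuration goes with the higher number.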